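Acetyl in Place of Trifluoromethyl: Expected Whole-Organism Activity

A few compounds are considered here, and "the series" means these few. Any claim that something is new, unique, unknown or untested is made for them only; others in the source may bear on it.

Three compounds have been measured in an ADME assay on the whole organism with Oryza sativa as the target, tested at 1 uM; a lower number here means a stronger effect, a higher number a weaker effect of the compound at the concentration tested:

Compound 1 `Cc1ccc(NC(=O)N[C@H](C)c2ccccc2)cc1` gives 98%.
Compound 2 `C[C@@H](NC(=O)Nc1ccc(C(C)(C)C)cc1)c1ccccc1` gives 88%.
Compound 3 `C[C@@H](NC(=O)Nc1ccc(C(F)(F)F)cc1)c1ccccc1` gives 89%.

Compound 3 holds the second highest of these three numbers. Its nearest neighbour is compound 2, with a step of a number 1 percentage points higher from compound 2 to compound 3 (within the scatter), and its furthest is compound 1, with a step of a number 9 percentage points lower from compound 1 to compound 3 (within the scatter); both of these lie within the scatter, so the three compounds cannot be ranked.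

Compound 4 `CC(=O)c1ccc(NC(=O)N[C@H](C)c2ccccc2)cc1` is not yet measured. It differs from compound 3 in one place: acetyl in place of trifluoromethyl on an aromatic carbon.

Going by the values given here, no measured step involves an acetyl group, so none bears directly on this change. The steps that exist, a number 10 percentage points lower from compound 1 to compound 2 (within the scatter) and a number 9 percentage points lower from compound 1 to compound 3 (within the scatter) as well as the one above, all stayed within the scatter when the group at this position was exchanged. The expectation is therefore a step of no size beyond the scatter, in no clear direction, written as a number 1 percentage points higher from compound 3 to compound 4 (within the scatter). Compound 4 is estimated at 90%, in a range from 78% to 100%.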

Compound 4, a percentage reported as activity, at one concentration (the size of the read-out at that concentration, not a potency): 93%
Compound 4: the middle estimate sits 3 percentage points below what was measured, within the range that was stated.
By their numbers in this assay, from the lowest: compounds 2, 3, 4 and 1 (each within the scatter of the next).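

Acetyl brings a hydrogen-bond acceptor to this position, para to a large group, where trifluoromethyl has none, and in this assay this exchange gives only a small step (a number 4 percentage points higher from compound 3 to compound 4 (within the scatter)). The steps against the other two groups (a number 5 percentage points higher from compound 2 to compound 4 (within the scatter) and a number 5 percentage points lower from compound 1 to compound 4 (within the scatter)) also stay within the scatter, so all four groups at this position now give numbers that cannot be told apart, and adding a carbonyl with its acceptor produced no readable effect. No measurement on any property of these groups is available to help interpret this result.

As far as these compounds go, what an amine, a carboxylic acid or a longer chain would do at this position remains open. From the compounds shown here alone, it is also open whether any exchange here, or elsewhere on the shared core, can move the number beyond the scatter.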